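Changing One Aryl Ring on a Shared Core

The source may hold more compounds than are shown below. What is called first, only, known or untested is meant among the compounds shown, and "the series" means these compounds.

Compound 1 `Cc1ccc(-c2ccnc(Nc3ccc4c(c3)c(/C=C3/C(=O)Nc5ccccc53)cn4C)n2)cc1` gives in a functional assay on U-87MG ATCC cells (Homo sapiens) for cytotoxicity, read by MTT assay, with a stated time of 48 h (on this read-out higher numbers stand for weaker inhibition and lower numbers for stronger inhibition), a limit rather than a number, > 100000 nM.
Compound 2 `Cn1cc(/C=C2/C(=O)Nc3ccccc32)c2cc(Nc3nccc(-c4ccc(Cl)cc4)n3)ccc21` gives 5820 nM.
Compound 3 `Cn1cc(/C=C2/C(=O)Nc3ccccc32)c2cc(Nc3nccc(-c4ccc(Cl)cc4Cl)n3)ccc21` gives 36800 nM.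

Among the two numbers shown, compound 3 stands highest; compound 2 is nearest, and a 6.3-fold higher number from compound 2 to compound 3 (0.80 log units; beyond the scatter). Compound 1 sits at the limit (the limit of > 100000 nM in this assay, at which 1 of the 3 values shown sits). Compound 4 `Cn1cc(/C=C2/C(=O)Nc3ccccc32)c2cc(Nc3nccc(-c4cccnc4)n3)ccc21` differs from compound 3 by one change, (pyridin-3-yl in place of 2,4-dichlorophenyl on an aromatic carbon). Changes at this ring have moved the numbers in both directions: an at least 17-fold lower number from compound 1 to compound 2 (1.23 log units; beyond the scatter), and an at least 2.7-fold lower number from compound 1 to compound 3 (0.43 log units; beyond the scatter), while the second chloro raised it again. Among the compounds with values here, no measured step introduces a ring nitrogen, so the direction is open. A number close to that of compound 3 is expected. Compound 4 is estimated at 30000 nM, within 6000 nM to 150000 nM. This expectation corresponds to a 1.2-fold lower number from compound 3 to compound 4 (0.09 log units; within the scatter).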

Compound 4, half-maximal inhibitory concentration: 14800 nM
Compound 4: middle estimate off by 2.0-fold (0.31 log units), on the high side, within the range that was stated.
By their numbers in this assay, from the lowest: compound 2; then compound 4; then compound 3. At a limit, above all of these: compound 1.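

At this position, in this assay, a ring with a nitrogen and no chloro falls within the range of the chlorinated rings rather than with the methyl-bearing one, with a 2.5-fold lower number from compound 3 to compound 4 (0.40 log units; beyond the scatter) and, on the other side, a 2.5-fold higher number from compound 2 to compound 4 (0.41 log units; beyond the scatter). Against the methyl-bearing ring, the result is an at least 6.7-fold lower number from compound 1 to compound 4 (0.82 log units; beyond the scatter), and that step gives only a bound. Compound 1 is a limit, not a number: the limit of > 100000 nM in this assay, at which 1 of the 4 values shown sits. Still open, from the compounds shown here alone, is whether moving the ring nitrogen, as in pyridin-4-yl, changes the value, and how an amine or carboxylic acid on this ring would behave.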